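The source may report more compounds than this note shows. Statements on the series, on what has been measured and on what is new or still open speak of the compounds shown alone.

Compound 1 `CCCCC1=Nc2ccccc2S(=O)(=O)N1Cc1ccc(-c2ccccc2C(=O)O)cc1` is followed here through one change. In an ADME assay for pharmacokinetics (on this read-out higher numbers stand for a longer-lived compound and lower numbers for a shorter-lived compound), compound 1 gives 7 h, the only plain number among the two results shown. Compound 2 `CCCCC1=NS(=O)(=O)c2ccccc2N1Cc1ccc(-c2ccccc2C(=O)O)cc1` is built on a differently arranged version of the shared core. Compound 2 reaches >> 24 h in this assay, which is a limit of the measurement and not a number; (the limit of >> 24 h in this assay, at which 1 of the 2 values shown sits). Compound 3 `CCCSC1=Nc2ccccc2S(=O)(=O)N1Cc1ccc(-c2ccccc2C(=O)O)cc1` has not yet been measured. It differs from compound 1 by propylsulfanyl in place of butyl on a carbon with a double bond to nitrogen. For the measured compounds named here, no measured step of this kind exists, so no shift beyond the usual scatter is expected. Compound 3 is estimated to give 7 h, between 3 h and 16 h. The expected step of no change at the digits printed from compound 1 to compound 3 (within the scatter) stays within scatter.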

Compound 3, half-life: >> 24 h
Compound 3: no number, only a limit; the forecaster's own chance of this, stated with the estimate: 10%; middle value at least 3.4-fold (0.53 log units) from the limit.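

In this assay putting propylsulfanyl in place of butyl gives an at least 3.4-fold higher number from compound 1 to compound 3 (0.53 log units; beyond the scatter) on a carbon with a double bond to nitrogen. Both groups hold 4 heavy atoms, so a swap that keeps this count can still move the half-life beyond the usual scatter. The full size of the step cannot be read, as compound 3 stands at a limit and not at a number: the limit of >> 24 h in this assay, at which 2 of the 3 values shown sit.

Going by these compounds, how a propoxy or propylamino chain would behave at this position stays open, as does the effect of the same swap on the differently arranged core of compound 2.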